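Permeability notes: amine side chain variation in the series

The compounds below may be only part of what the source reports. "The series", "measured", "known", "first", "only" and "open" are said of these compounds alone.

Among the measured compounds shown here, compound 2 `CCN1CCN(c2cc(C)c3cc(NC(=O)c4ccc(Cl)c(Cl)c4)ccc3n2)CC1` stands at the top of the two numbers measured so far: in an ADME assay for permeability, using PAMPA, at pH 7.4 (a higher number here means that the compound crosses the layer faster, a lower number that the compound crosses the layer more slowly), compound 2 gives 25.9 10^-6 cm/s. For the measured compounds named here, its only neighbour, compound 1 `Cc1cc(NCCN2CCCC2)nc2ccc(NC(=O)c3ccc(Cl)c(Cl)c3)cc12`, gives 20.8 10^-6 cm/s, and the step between them, a 1.2-fold higher number from compound 1 to compound 2 (0.10 log units; within the scatter), does not separate the two beyond the scatter, so no order between compound 1 and compound 2 can be claimed.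

Compound 3 `Cc1cc(NCCN2CCCCC2)nc2ccc(NC(=O)c3ccc(Cl)c(Cl)c3)cc12` is the next point in this direction, differing from compound 2 as follows: (2-(piperidin-1-yl)ethyl)amino in place of 4-ethylpiperazin-1-yl on an aromatic carbon. Going by the values given here, the single measured step is the one that bears on it, since it also exchanges the amine side chain at the same aromatic carbon, and it stayed within the scatter. On that basis the step from compound 2 to compound 3 is expected to be small, a 1.2-fold lower number from compound 2 to compound 3 (0.07 log units; within the scatter), with no direction that the data support. Compound 3 is therefore estimated at 22 10^-6 cm/s, with a range from 13 10^-6 cm/s to 36 10^-6 cm/s.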

Compound 3, apparent permeability in the ADME assay: 47.3 10^-6 cm/s
Compound 3: the middle estimate sits 2.2-fold (0.33 log units) below what was measured, and the stated range ends below it.
By their numbers in the ADME assay, from the lowest: compounds 1, 2 and 3 (each within the scatter of the next, the first and the last beyond it).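

Among the compounds shown here, the ring at the end of the chain now counts: in the ADME assay, a 2.3-fold higher number from compound 1 to compound 3 (0.36 log units; beyond the scatter), the first step to pass the scatter, with piperidin-1-yl in place of pyrrolidin-1-yl and the rest of the side chain unchanged. Exchanging the whole side chain still gives no order, since a 1.8-fold higher number from compound 2 to compound 3 (0.26 log units; within the scatter), so compound 3 cannot be placed apart from compound 2. In a physicochemical assay for lipophilicity, at pH 7.4 (a lower number here means a more polar compound, a higher number a more lipophilic compound), compound 2 gives 3.67 and compound 3 gives 2.72, and this gap is not matched by a step beyond the scatter in the ADME assay.

From the compounds shown here alone, it remains open whether a morpholin-4-yl ring on the same chain would follow piperidin-1-yl or pyrrolidin-1-yl in the ADME assay. Going by these compounds, a longer chain between the aromatic amine and the ring is equally open.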